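Moving the aryl group onto the sulfur-bound carbon

The source may hold more compounds than are shown below. What is called first, only, known or untested is meant among the compounds shown, and "the series" means these compounds.

Compound 1 `O=C(O)Cn1c(SCCc2ccccc2)nc2ccccc21` gives 881 nM in an assay on HEK293 cells for displacement of a labelled ligand from prostaglandin D2 receptor 2 (Homo sapiens); a lower number here means a stronger inhibitor, a higher number a weaker inhibitor.
Compound 2 `O=C(O)Cn1c(SCCCNc2ccccc2)nc2ccccc21` gives 2690 nM in this assay.
Compound 3 `CCOC(=O)CCSc1nc2ccccc2n1CC(=O)O` gives 11400 nM in this assay.

Compound 3 has the highest number of the three. The step to compound 4 `O=C(O)Cn1c(SCc2cccc(Cl)c2)nc2ccccc21` is 3-chlorophenyl in place of (ethoxycarbonyl)methyl on a saturated chain carbon bound to a sulfur. Within the data shown here, the steps that bear on it are the ones that also exchanged the group two bonds along the chain from the sulfur: a 13-fold higher number from compound 1 to compound 3 (1.11 log units; beyond the scatter) and a 4.2-fold higher number from compound 2 to compound 3 (0.63 log units; beyond the scatter). An aromatic ring in place of the ester therefore points to a clearly lower number in this assay, and compound 4 is expected to show a 14-fold lower number from compound 3 to compound 4 (1.15 log units; beyond the scatter). Compound 4 is estimated at 800 nM, within 250 nM to 3000 nM.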

Compound 4, half-maximal inhibitory concentration: 186 nM
Compound 4: middle estimate off by 4.3-fold (0.63 log units), on the high side; the whole stated range lies above it.
By their numbers in this assay, from the lowest: compound 4; then compound 1; then compound 2; then compound 3.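

In this assay, 3-chlorophenyl on a saturated chain carbon bound to a sulfur gives a 61-fold lower number from compound 3 to compound 4 (1.79 log units; beyond the scatter) against (ethoxycarbonyl)methyl, and a 4.7-fold lower number from compound 1 to compound 4 (0.68 log units; beyond the scatter) against benzyl. An aromatic ring at this place therefore does more than lower the number relative to the ester: compound 4 also falls below compound 1, the lowest earlier compound, with its ring further along the chain. Nothing at hand explains this result. Going by these compounds, compound 1 and compound 4 differ in both chain length and chlorine, so the share of each remains open. On these data alone, how a fluorine or a methoxy group in place of the chlorine would read is also open.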